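Thiophene-to-furan swap on a pyridine series: cytotoxicity notes

The source may hold more compounds than are shown below. What is called first, only, known or untested is meant among the compounds shown, and "the series" means these compounds.

Compound 1 `c1csc(-c2cc(-c3ccncc3)nc(-c3ccsc3)c2)c1` and compound 2 `c1cncc(-c2cc(-c3ccsc3)cc(-c3cccs3)n2)c1` have been measured in a functional assay on A549 cells (Homo sapiens) for cytotoxicity, read by sulforhodamine B assay, with a stated time of 48 h; a lower number here means a stronger inhibitor, a higher number a weaker inhibitor. Compound 1 gives 5690 nM in this assay, while compound 2 gives 2730 nM in this assay, the lower of the two numbers and beyond the scatter from compound 1. Compound 3 `c1cncc(-c2cc(-c3ccco3)cc(-c3cccs3)n2)c1` is not yet measured; it differs from compound 2 by furan-2-yl in place of thiophen-3-yl on an aromatic carbon. Going by the values given here, no single-change step between measured compounds exists here, so no size of effect can be read off. The step from compound 2 to compound 3 in this assay is expected to be a 1.1-fold higher number from compound 2 to compound 3 (0.04 log units; within the scatter), not beyond the scatter in either direction. Compound 3 is estimated at 3000 nM in this assay, in a range of 1200 nM to 7500 nM.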

Compound 3, half-maximal inhibitory concentration: 14500 nM
Compound 3: the middle estimate sits 4.8-fold (0.68 log units) below what was measured, outside the stated range (above it).
By their numbers in this assay, from the lowest: compound 2; then compound 1; then compound 3.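

In this assay, the position opposite the ring nitrogen does not tolerate every five-membered aromatic ring equally: furan-2-yl in place of thiophen-3-yl gives a 5.3-fold higher number from compound 2 to compound 3 (0.73 log units; beyond the scatter). The two groups have the same counts of heavy atoms, donors and acceptors, so those counts do not separate them. Nothing measured on hand explains the step.

The compounds shown leave open whether the step follows the ring oxygen or the point of attachment, which furan-3-yl at this position would separate. On these data alone, how an amine or a carboxylic acid would read here also remains open.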